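The source may hold more compounds than are shown below. What is called first, only, known or untested is meant among the compounds shown, and "the series" means these compounds.

Measured in a toxicity assay on NIH3T3 cells (Mus musculus) for cytotoxicity, read by resazurin assay; on this read-out lower numbers stand for an effect already at smaller amounts and higher numbers for an effect only at larger amounts of compound:
- Compound 1 `CC(=O)c1ccc(NCc2cncn2Cc2ccc(-c3ccccc3)cc2)cc1-c1ccccc1`: > 10000 nM, a limit.
- Compound 2 `Clc1ccc(NCc2cncn2Cc2ccc(-c3ccccc3)cc2)cc1-c1ccccc1`: > 1000 nM, a limit.
- Compound 3 `CN(C)c1ccc(NCc2cncn2Cc2ccc(-c3ccccc3)cc2)cc1-c1ccccc1`: > 1000 nM, a limit.

Compound 3 has no exact number, only (the limit of > 1000 nM in this assay, at which 2 of the 3 values shown sit). Compound 4 `c1ccc(-c2ccc(Cn3cncc3CNc3cccc(-c4ccccc4)c3)cc2)cc1` differs from it in one place: hydrogen in place of dimethylamino on an aromatic carbon, which is hydrogen in place of dimethylamino on an aromatic carbon. Three measured steps change a group on that same carbon: a step that the two limits leave unreadable from compound 1 to compound 2, a step that the two limits leave unreadable from compound 1 to compound 3 and a step that the two limits leave unreadable from compound 2 to compound 3. None of them has a readable size, so they give no sign of a shift in either direction. A step beyond the usual scatter is therefore not expected, and another limit is the likeliest result. The expected change is a step that the limit leaves unreadable from compound 3 to compound 4. For compound 4 the estimate is 5000 nM, with an expected range from 1500 nM to 20000 nM.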

Compound 4, half-maximal effective concentration: 10000 nM
Beside the measured number, compound 4's estimate is 2.0-fold (0.30 log units) below it; the measured number falls inside the stated range.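

In this assay, going by these compounds alone, compound 4, with a hydrogen on this aromatic carbon, gives 10000 nM, the first exact number at this position. Hydrogen in place of acetyl gives a number no higher from compound 1 to compound 4 (the limit leaves the size open). As far as these compounds go, the steps to compound 4 from compounds 2 and 3 cannot be read, as each of those two compounds has only a limit, so the size of replacing chloro or dimethylamino with hydrogen stays unknown.

The compounds shown leave open whether any group on this carbon shifts the number at all. A carboxylic acid or a methoxy group there is also an open case.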